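This account rests on a few compounds, and the source may have more. Where it says the series, first, only, none or still open, it means among the compounds named here.

Of the compounds shown here, three sharing one core have been measured, and a fourth awaits its number. Compound 1 `CC1(C)N=C(N)N=C(N)N1c1ccc(OCc2ccc(S(=O)(=O)F)cc2)c(Cl)c1` gives 7.58 in an assay on isolated protein for inhibition of Dihydrofolate reductase (Mus musculus); on this read-out higher numbers stand for higher potency (the scale is a negative logarithm) and lower numbers for lower potency. Compound 3 `CC1(C)N=C(N)N=C(N)N1c1ccc(OCc2ccc(S(=O)(=O)F)c(Cl)c2)c(Cl)c1` gives 7.43 in this assay, and compound 2 `CC1(C)N=C(N)N=C(N)N1c1ccc(Cl)c(CCc2ccc(S(=O)(=O)F)cc2)c1` gives 5.82 in this assay.

The step from compound 3 to compound 1 is hydrogen in place of chloro on an aromatic carbon, and it made a number 0.15 log units higher from compound 3 to compound 1 (within the scatter). Compound 2 stands lowest of the three, its distance to compound 3 and to compound 1 each lying beyond the scatter. The difference between the cores of compound 2 and compound 3 is not broken down here.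

Compound 4 `CC1(C)N=C(N)N=C(N)N1c1cccc(CCc2ccc(S(=O)(=O)F)cc2)c1` is still to be measured in this assay. It arises from compound 2 by hydrogen in place of chloro on an aromatic carbon. This is the same kind of change as that from compound 3 to compound 1, not the same: there the place was ortho to a fluorosulfonyl group and meta to a large group, here it is ortho to a large group and para to a large group. Because a number 0.15 log units higher from compound 3 to compound 1 (within the scatter) stayed within the scatter, a similarly small step is expected, a number 0.08 log units higher from compound 2 to compound 4 (within the scatter). Compound 4 is thus estimated at 5.9, between 5.3 and 6.5.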

Compound 4, logarithm of the reciprocal of the active concentration, log(1/C): 8.1
The estimate for compound 4 lay 2.20 log units below the measured number, outside the stated range (above it).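

Replacing chloro with hydrogen on an aromatic carbon gave a number 2.28 log units higher from compound 2 to compound 4 (beyond the scatter) in this assay, so in this series the size of this change does not carry over from one core to another: the same change on two cores in this assay, a number 0.15 log units higher (within the scatter) from compound 3 to compound 1 and a number 2.28 log units higher (beyond the scatter) from compound 2 to compound 4, 2.13 log units apart, beyond the scatter of two such steps

The result shows that the small step on one core gave no guide to the large step on the other. It does not show why they differ, since the two pairs differ both in the rest of the molecule and in where the chloro sits, and a single pair on each core cannot separate these two differences.

From the compounds shown here alone, it remains open how a fluoro, a methyl or a methoxy group in place of the chloro of compound 2 would compare with chloro and hydrogen. Also open, going by these compounds, is what the same replacement would do at the other chloro of compound 1, and how a longer chain linking the two rings of compound 4 would fare.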